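Trading the iodophenyl end group for a pyridyl ring

The source may report more compounds than this note shows. Statements on the series, on what has been measured and on what is new or still open speak of the compounds shown alone.

In a functional assay on 1321-N1 cells for agonist activity at P2Y purinoceptor 6 (Homo sapiens), read by scintillation counting and inositol phosphate accumulation (a lower number here means that less compound is needed, a higher number that more compound is needed for the effect), compound 2 `O=c1[nH]/c(=N\OCCCc2cccc(I)c2)ccn1[C@@H]1O[C@H](COP(=O)(O)OP(=O)(O)OP(=O)(O)O)[C@@H](O)[C@H]1O` gives 299 nM, the lowest of the three measured numbers. Compound 1 `O=c1[nH]/c(=N\OCCCc2ccc(F)cc2)ccn1[C@@H]1O[C@H](COP(=O)(O)OP(=O)(O)OP(=O)(O)O)[C@@H](O)[C@H]1O` gives 1210 nM, and compound 3 `O=c1[nH]/c(=N\OCCCc2ccc([N+](=O)[O-])cc2)ccn1[C@@H]1O[C@H](COP(=O)(O)OP(=O)(O)OP(=O)(O)O)[C@@H](O)[C@H]1O` gives 1330 nM. The two measured steps that touch the aromatic ring at the end of the chain are a 4.0-fold lower number from compound 1 to compound 2 (0.61 log units; beyond the scatter) and a 4.4-fold higher number from compound 2 to compound 3 (0.65 log units; beyond the scatter); both are modest and both run beyond the scatter. Compound 4 `O=c1[nH]/c(=N\OCCCc2cccnc2)ccn1[C@@H]1O[C@H](COP(=O)(O)OP(=O)(O)OP(=O)(O)O)[C@@H](O)[C@H]1O` changes the same region of compound 2: pyridin-3-yl in place of 3-iodophenyl on a saturated chain carbon, three bonds along the chain from an oxygen. Of the measured compounds, only compound 2 carries the 3-iodophenyl group, and the two compounds with a different ring, compound 1 and compound 3, both give higher numbers in this assay. Compound 4 has no iodine and no substituent on its ring at all, so a higher number is expected, roughly a 5.0-fold higher number from compound 2 to compound 4 (0.70 log units; beyond the scatter). The estimated value for compound 4 in this assay is 1500 nM, with an expected range from 400 nM to 5500 nM.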

Compound 4, half-maximal effective concentration: 2950 nM
Compound 4: middle estimate off by 2.0-fold (0.29 log units), on the low side; measured number inside the range.
By their numbers in this assay, from the lowest: compound 2; then compounds 1 and 3 (each within the scatter of the next); then compound 4.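

In this assay the change to pyridin-3-yl produces a 9.9-fold higher number from compound 2 to compound 4 (0.99 log units; beyond the scatter) as the largest step yet seen at this place, so the group on the chain can move the number further than the earlier ring changes showed. The pyridin-3-yl ring also gives a higher number than the two rings without iodine, with a 2.4-fold higher number from compound 1 to compound 4 (0.39 log units; beyond the scatter) and a 2.2-fold higher number from compound 3 to compound 4 (0.35 log units; beyond the scatter) beyond the scatter, so compound 4 does not merely join compounds 1 and 3 but sits above them. No measured evidence on the cause of these steps is available. The compounds shown do not separate the effect of adding the ring nitrogen from that of losing the iodine, which a plain phenyl ring on the same chain would help to do. They also leave open how a 3-bromophenyl group or a pyridin-3-yl ring carrying iodine would compare.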